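Dimethylaminophenyl Amide Tested Against a Carbamoylphenyl Lead

The compounds below may be only part of what the source reports. "The series", "measured", "known", "first", "only" and "open" are said of these compounds alone.

Within the data shown here, compound 1 `NC(=O)c1ccc(C(=O)N2CCC(N(C3CC3)S(=O)(=O)c3cccc(C(F)(F)F)c3)CC2)cc1` is the only member of the series with a number: in an assay on cells for inhibition of Voltage-dependent L-type calcium channel subunit alpha-1C (Homo sapiens), read by FLIPR and calcium flux, tested at 1 uM (on this read-out lower numbers stand for a weaker effect and higher numbers for a stronger effect at the one concentration tested), compound 1 gives 0%, the weakest possible reading. Compound 2 `CS(=O)(=O)c1ccc(C(=O)N2CCC(N(C3CC3)S(=O)(=O)c3cccc(C(F)(F)F)c3)CC2)cc1` carries a methylsulfonyl group in its place, and in this assay compound 2 shows "not determined" (no result reported), so no result is reported for it. Compound 3 `CN(C)c1cccc(C(=O)N2CCC(N(C3CC3)S(=O)(=O)c3cccc(C(F)(F)F)c3)CC2)c1` differs from compound 1 by 3-(dimethylamino)phenyl in place of 4-carbamoylphenyl on a carbonyl carbon. Among the measured compounds shown here, no comparable step has been measured, so the expected change from compound 1 to compound 3 is taken to be a number 5 percentage points higher from compound 1 to compound 3 (within the scatter), probably no more than the scatter. Compound 3 is therefore estimated at 5%, between -10% and 25%.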

Compound 3, a percentage reported as inhibition, at one concentration (the size of the read-out at that concentration, not a potency): 40%
Compound 3: middle estimate off by 35 percentage points, on the low side, outside the stated range (above it).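

In this assay, 3-(dimethylamino)phenyl in place of 4-carbamoylphenyl on a carbonyl carbon gives a number 40 percentage points higher from compound 1 to compound 3 (beyond the scatter), so the read-out responds to this position while the rest of the molecule stays the same. Nothing shown bears on why the step occurs. The two groups differ both in their substituent and in where their names place it, and the compounds shown do not separate these two changes. They also leave open how a carboxylic acid or a primary amine on this phenyl would read.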